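The source may hold more compounds than are shown below. What is called first, only, known or untested is meant among the compounds shown, and "the series" means these compounds.

Within the data shown here, in a functional assay on HepG2 cells (Homo sapiens) for antiproliferative activity, read by MTT assay, with a stated time of 24 h (a lower number here means a stronger inhibitor, a higher number a weaker inhibitor), three compounds on a shared core have numbers so far. Compound 1 (`COc1ccc(C(=O)/C=C/c2ccc(N(C)C)cc2)c2c1C=CC(C)(C)O2`) gives 730 nM as its value, the second highest of the three. Compound 2 (`COc1ccc(C(=O)/C=C/c2ccc3ccccc3c2)c2c1C=CC(C)(C)O2`) gives 210 nM as a lower number, beyond the scatter from compound 1. Compound 3 (`COc1ccc(C(=O)/C=C/c2ccc3ccccc3n2)c2c1C=CC(C)(C)O2`) gives 4280 nM as a higher number, also beyond the scatter from compound 1. Among the measured compounds shown here, no two measured compounds differ in one place only, so no direct step is available as a guide.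

Compound 4 (`COc1ccc(C(=O)/C=C/c2ccccc2)c2c1C=CC(C)(C)O2`) has not been measured. It differs from compound 1 by hydrogen in place of dimethylamino on an aromatic carbon, para to a large group (hydrogen in place of dimethylamino on an aromatic carbon). For the measured compounds named here, the measured compounds contain no example of this change, so the expectation rests only on the range they span, with compound 2 at 210 nM as one end and compound 3 at 4280 nM as the other. The expected step is a 1.9-fold higher number from compound 1 to compound 4 (0.28 log units; within the scatter) as a modest move toward a higher number in this assay near the edge of the scatter, with no firm direction. For compound 4 the estimate is 1400 nM as the expected value, with an expected range from 350 nM to 5000 nM as its bounds.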

Compound 4, half-maximal inhibitory concentration: > 10000 nM
Compound 4 ended at the assay's limit; the forecaster's own chance of this, stated with the estimate: 3%; middle value at least 7.1-fold (0.85 log units) from the limit.
By their numbers in this assay, from the lowest: compound 2; then compound 1; then compound 3. At a limit, above all of these: compound 4.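

In this assay, among these compounds, hydrogen in place of dimethylamino on an aromatic carbon, para to a large group, is the first single-place change available, and it gives an at least 13-fold higher number from compound 1 to compound 4 (1.13 log units; beyond the scatter) on this evidence. Compound 4 gives > 10000 nM as a limit of the assay, so the step fixes only a lower bound and the full size of the change stays unread: the limit of > 10000 nM in this assay, at which 1 of the 4 values shown sits. Even so, the position is not indifferent to substitution: with dimethylamino on this aromatic carbon the number lies within the measurable range of the assay, and with hydrogen it does not, a contrast that the earlier compounds, with no single-place pair among them, could not show.

Still open, from the compounds shown here alone, is whether the nitrogen of dimethylamino matters here or whether other groups on the same aromatic carbon would also bring the number back within range, a question that an unsubstituted amino group, a diethylamino group or a chlorine atom at this place would address. Among the compounds shown here, whether the same change acts alike on other versions of the shared core also remains unsettled, since the series holds only this one pair.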